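The source may report more compounds than this note shows. Statements on the series, on what has been measured and on what is new or still open speak of the compounds shown alone.

The study compares four analogues that share a cyclobutenedione core carrying a hydroxamic acid side chain. Compound 1 `O=C(CCCCCNc1c(NCc2ccccc2)c(=O)c1=O)NO` and compound 2 `C[C@H](Nc1c(NCCCCCC(=O)NO)c(=O)c1=O)c1ccccc1` differ by methyl in place of hydrogen on a saturated chain carbon bound to an aromatic carbon and a nitrogen on an aromatic ring. Compound 3 `CC(CCCCC(=O)NO)Nc1c(Nc2ccc(C(F)(F)F)cc2)c(=O)c1=O` and the not yet measured compound 4 `CCC(CCCCC(=O)NO)Nc1c(Nc2ccc(C(F)(F)F)cc2)c(=O)c1=O` differ by methyl in place of hydrogen on a saturated chain carbon, two bonds along the chain from a nitrogen on an aromatic ring, the same kind of change, though here the saturated chain carbon sits two bonds along the chain from a nitrogen on an aromatic ring rather than bound to an aromatic carbon and that nitrogen. The difference between the core of compound 1 and the core of compound 3 is not broken down here.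

In an ADME assay on cells (Hepatocyte, Homo sapiens) for pharmacokinetics, read by LC-MS, with a stated time of 90 min, tested at 1 uM (on this read-out higher numbers stand for fast clearance and lower numbers for slow clearance), compound 1 gives < 4.8 uL/min, a limit of the assay. Compound 2 gives < 5 uL/min in this assay, again a limit. The step that the two limits leave unreadable from compound 1 to compound 2 therefore cannot be sized, because the limit of < 4.8 uL/min in this assay, at which 1 of the 3 values shown sits, and the limit of < 5 uL/min in this assay, at which 1 of the 3 values shown sits, cap both values. For the measured compounds named here, compound 3 gives 21 uL/min in this assay, the only real number among the three.

For compound 4 a step of a 1.2-fold higher number from compound 3 to compound 4 (0.09 log units; within the scatter) is expected, resting on compound 3 at 21 uL/min and on the unreadable step in compound 1 and compound 2. Compound 4 is thus estimated at 26 uL/min, within 11 uL/min to 55 uL/min.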

Compound 4, intrinsic clearance in a liver preparation (reported as CLH), per the amount of preparation that the assay uses: 25 uL/min
The estimate for compound 4 lay 1.0-fold (0.02 log units) above the measured number, within the range that was stated.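

In this assay, methyl in place of hydrogen on a saturated chain carbon, two bonds along the chain from a nitrogen on an aromatic ring, gives a 1.2-fold higher number from compound 3 to compound 4 (0.08 log units; within the scatter), which shows that on the core of compound 3 this single change stays inside the usual scatter. The matching change on the core of compound 1 sits on a different carbon, bound to an aromatic carbon and a nitrogen on an aromatic ring, and its step cannot be read, as compound 1 stands at a limit: the limit of < 4.8 uL/min in this assay, at which 1 of the 4 values shown sits. Compound 2 also stands at a limit, so the pair does not show whether the result on one core carries over to the other: the limit of < 5 uL/min in this assay, at which 1 of the 4 values shown sits.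

The compounds shown leave open how a propyl chain, an amine or a carboxylic acid on that saturated chain carbon would read in this assay. They also leave open whether the methyl change would give the same result with a nitrile in place of the trifluoromethyl group.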